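Chain-to-ring swap at the amine of the shared core

This account rests on a few compounds, and the source may have more. Where it says the series, first, only, none or still open, it means among the compounds named here.

Compound 1 `COCCNC(=O)CCNc1ncc2c(Br)nn(-c3ccc4ncccc4c3)c2n1` carries a 2-((2-methoxyethyl)carbamoyl)ethyl group on the amine nitrogen of the shared core. On these data alone, in an assay on SK-OV-3 cells for inhibition of eIF-2-alpha kinase GCN2 (Homo sapiens) (on this read-out lower numbers stand for stronger inhibition and higher numbers for weaker inhibition), compound 1 has "nd" (no result reported), so where compound 1 stands on this read-out remains open. Two relatives with a ring in that position have numbers. In this assay compound 2 `COCCNC(=O)[C@H]1CC[C@H](Nc2ncc3c(Br)nn(-c4ccc5ncccc5c4)c3n2)C1` gives 183 nM. In this assay compound 3 `COCCNC(=O)[C@H]1CC[C@@H](Nc2ncc3c(Br)nn(-c4ccc5ncccc5c4)c3n2)CC1` gives 763 nM. Compound 4 `Brc1nn(-c2ccc3ncccc3c2)c2nc(N[C@@H]3CC[C@@H](c4ncc[nH]4)C3)ncc12` differs from compound 1 as follows: a group of 10 heavy atoms (8 carbon, 2 nitrogen; one five-membered non-aromatic ring of carbon only, one five-membered aromatic ring with 2 hetero atoms) in place of a group of 9 heavy atoms (6 carbon, 1 nitrogen, 2 oxygen; no ring), on a nitrogen on an aromatic ring. Within the data shown here, no step from compound 1 to compound 4 can be computed, and with compound 1 itself unmeasured neither a size nor a direction for that step in this assay can be stated from the data. Among the measured compounds shown here, the expectation for compound 4 therefore rests on the values of compound 2 and compound 3 alone, as the only measured members. Compound 4 is expected to give about 200 nM in this assay, with a range from 50 nM to 800 nM.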

Compound 4, half-maximal inhibitory concentration: 545 nM
Beside the measured number, compound 4's estimate is 2.7-fold (0.44 log units) below it, within the range that was stated.
By their numbers in this assay, from the lowest: compound 2; then compounds 4 and 3 (each within the scatter of the next).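

No new step can be read for compound 1 and compound 4 in this assay. No measurement shown bears on a cause for this result. The compounds shown leave open how replacing the 2-((2-methoxyethyl)carbamoyl)ethyl group of compound 1 with the ring-bearing group of compound 4 shifts the value in this assay.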